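Ring-size swap at the ether oxygen of the biphenyl series

The source may hold more compounds than are shown below. What is called first, only, known or untested is meant among the compounds shown, and "the series" means these compounds.

Measured so far:
compound 1 `N#CN1CC(OCc2ccc(-c3ccccc3)cc2)C1`, 2.8 nM
compound 2 `N#CN1CC(COCc2ccc(-c3ccccc3)cc2)C1`, 3.4 nM

In an assay on isolated protein for inhibition of N-acylethanolamine-hydrolyzing acid amidase (Homo sapiens), read by fluorescence, with a stated time of 90 min (on this read-out lower numbers stand for stronger inhibition and higher numbers for weaker inhibition), compound 2 stands highest of the two numbers, its nearest neighbour being compound 1, and the step of a 1.2-fold higher number from compound 1 to compound 2 (0.08 log units; within the scatter) lies within the scatter. Compound 3 `N#CN1CC[C@@H](OCc2ccc(-c3ccccc3)cc2)C1` differs from compound 2 by 1-cyanopyrrolidin-3-yl in place of (1-cyanoazetidin-3-yl)methyl on an oxygen on a saturated carbon. Going by the values given here, the only measured step bearing on it is that insertion of a methylene between ring and oxygen, which changed nothing beyond the scatter; this change keeps the same atoms and a similar spacing. No step beyond the scatter is therefore expected, and the estimated step is a 1.2-fold higher number from compound 2 to compound 3 (0.07 log units; within the scatter). Compound 3 is expected to give 4 nM, with a range of 1.5 nM to 12 nM.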

Compound 3, half-maximal inhibitory concentration: 26.4 nM
The estimate for compound 3 lay 6.6-fold (0.82 log units) below the measured number, and the stated range ends below it.
By their numbers in this assay, from the lowest: compounds 1 and 2 (each within the scatter of the next); then compound 3.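

On an oxygen on a saturated carbon, this position tolerates the added methylene but not every arrangement of the same atoms: in this assay the change to 1-cyanopyrrolidin-3-yl gives a 7.8-fold higher number from compound 2 to compound 3 (0.89 log units; beyond the scatter) and also a 9.4-fold higher number from compound 1 to compound 3 (0.97 log units; beyond the scatter). Going by these compounds alone, the earlier pair showed only that the two azetidine groups read alike, whereas the five-membered ring now separates from both. No evidence on hand accounts for this step.

As far as these compounds go, whether the opposite configuration of 1-cyanopyrrolidin-3-yl would read nearer compound 1 or compound 3 remains open. The same question stands for 1-cyanopiperidin-4-yl on this oxygen.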